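The compounds below may be only part of what the source reports. "The series", "measured", "known", "first", "only" and "open" are said of these compounds alone.

Measured compounds:
compound 1 `CN1CCC(C(=O)N2Cc3c(NC(=O)C4CCC4)n[nH]c3C2(C)C)CC1`, > 225000 nM;
compound 2 `CN1CCC(C(=O)N2Cc3c(NC(=O)c4cccc(F)c4)n[nH]c3C2(C)C)CC1`, > 225000 nM.

In a physicochemical assay for solubility, at pH 7 (a higher number here means a more soluble compound, a lower number a less soluble compound), compound 1 gives > 225000 nM, which is a limit of the assay rather than a number. In the same assay compound 2 gives > 225000 nM, again a limit of the assay. Compound 2 therefore stands at the upper edge of what this assay reports, and the step that the two limits leave unreadable from compound 1 to compound 2 cannot be read, since both ends sit at a limit (the limit of > 225000 nM in this assay, at which 2 of the 2 values shown sit).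

The unmeasured compound 3 `CN1CCC(C(=O)N2Cc3c(NC(=O)c4ccc(C(F)(F)F)cc4)n[nH]c3C2(C)C)CC1` differs from compound 2 in one place: 4-(trifluoromethyl)phenyl in place of 3-fluorophenyl on a carbonyl carbon. No measured step bears readably on this change; the only step shown, from compound 1 to compound 2, is hidden by the limit on both sides. Compound 3 is therefore expected to remain near the limit, with an estimated step of an at least 1.1-fold lower number from compound 2 to compound 3 (0.05 log units; that floor lies within the scatter) that cannot be distinguished from none. The estimate for compound 3 in this assay is 200000 nM, in the range 50000 nM to 600000 nM.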

Compound 3, solubility: 191000 nM
Estimate against measurement, compound 3: 1.0-fold (0.02 log units) above; measured number inside the range.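

In this assay, for the compounds shown here, compound 3 gives 191000 nM, the first reading in this set that is a number and not a limit, so the series now has a measured value with 4-(trifluoromethyl)phenyl on the carbonyl carbon. The change from 3-fluorophenyl is an at least 1.1-fold lower number from compound 2 to compound 3 (0.07 log units; that floor lies within the scatter), and the change from cyclobutyl is an at least 1.1-fold lower number from compound 1 to compound 3 (0.07 log units; that floor lies within the scatter); both are floors within the scatter, so neither shows a real drop, though a larger true step is not excluded. The other two compounds give no number to set against it: the limit of > 225000 nM in this assay, at which 2 of the 3 values shown sit.

As far as these compounds go, how far compound 3 truly lies from compound 1 and compound 2 therefore stays open. Also open, from the compounds shown here alone, is how this assay would read with an amine, a carboxylic acid or a longer chain on this carbonyl carbon.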